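This account rests on a few compounds, and the source may have more. Where it says the series, first, only, none or still open, it means among the compounds named here.

Compound 1 `COc1ccc(Cl)cc1NC(=O)N1CC2(CCN(S(=O)(=O)N3CCC(C)CC3)CC2)C1` – in an assay on HEK293 cells for activation of potassium channel subfamily T member 1 (Homo sapiens), read by thallium flux (on this read-out higher numbers stand for an effect only at larger amounts of compound and lower numbers for an effect already at smaller amounts), compound 1 gives > 10000 nM, a limit of the assay.
Compound 2 `COc1ccc(NC(=O)CN2CCN(S(=O)(=O)N3CCC(C)CC3)CC2)cc1` – in this assay compound 2 gives > 10000 nM, again a limit.
Compound 3 `COc1ccc(Cl)cc1NC(=O)CN1CCN(S(=O)(=O)N2CCN(C(=O)N3CCCCCC3)CC2)CC1` – in this assay compound 3 gives > 10000 nM, also a limit.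

Compound 3 therefore stands nowhere in particular among the three: its value is a limit rather than a number, and the other two values are limits as well. What the data show is summed up in one line: the limit of > 10000 nM in this assay, at which 3 of the 3 values shown sit. Going by the values given here, no step between measured compounds is available to lean on.

Compound 4 `COc1ccc(Cl)cc1NC(=O)CN1CCN(S(=O)(=O)N2CCN(C(=O)N3CCCCC3)CC2)CC1` is the compound still to be measured. It differs from compound 3 in a single place: piperidin-1-yl in place of azepan-1-yl on a carbonyl carbon. Among the compounds with values here, nothing measured here speaks to the effect of this change, since no pair of measured compounds differs in the same way.

With all three known values sitting at the limit, the expectation for compound 4 is that it stays there as well. The step that the limit leaves unreadable from compound 3 to compound 4 is expected to be none beyond the scatter. Compound 4 is expected at 15000 nM in this assay, with a range from 4000 nM to 60000 nM, and most likely reported only as a limit.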

Compound 4, half-maximal effective concentration: > 10000 nM
Compound 4: a limit, no number; the forecaster's own chance of this, stated with the estimate: 80%; the middle value is on the limit's open side.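

Compound 3 and compound 4 both sit at a limit in this assay, so no step between them can be read: the limit of > 10000 nM in this assay, at which 4 of the 4 values shown sit.

The compounds shown leave open how piperidin-1-yl and azepan-1-yl on the carbonyl carbon compare, and which structure, if any, would give a measurable value in this assay.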